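Hexyloxy in Place of Isobutyl After a Flat Step

The source may report more compounds than this note shows. Statements on the series, on what has been measured and on what is new or still open speak of the compounds shown alone.

In a functional assay on brain (Rattus norvegicus, strain Wistar) for inhibition (on this read-out higher numbers stand for weaker inhibition and lower numbers for stronger inhibition), compound 1 (`CCCCOc1ccc(-c2c(C)[nH]c(=O)n2C2CCCCC2)cc1`) gives 13900 nM and compound 2 (`Cc1[nH]c(=O)n(C2CCCCC2)c1-c1ccc(CC(C)C)cc1`) gives 10900 nM as its reading. Among the compounds with values here, these two values lie within the scatter of each other, so compound 2 cannot be separated from the only other compound measured. Compound 3 (`CCCCCCOc1ccc(-c2c(C)[nH]c(=O)n2C2CCCCC2)cc1`) carries hexyloxy in place of isobutyl on an aromatic carbon, para to a large group (hexyloxy in place of isobutyl on an aromatic carbon). Within the data shown here, one measured step bears on this change: isobutyl in place of butoxy on an aromatic carbon gave a 1.3-fold lower number from compound 1 to compound 2 (0.11 log units; within the scatter) and so no change that can be read. This single small step offers no basis for expecting a shift beyond the scatter in this assay and suggests no direction. The expected step is a 1.1-fold lower number from compound 2 to compound 3 (0.04 log units; within the scatter) and remains an estimate. For compound 3 the estimated value is 10000 nM with an expected range from 3500 nM to 30000 nM in this read-out.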

Compound 3, half-maximal inhibitory concentration: 8500 nM
The estimate for compound 3 lay 1.2-fold (0.07 log units) above the measured number, and the stated range covers the measured number.
By their numbers in this assay, from the lowest: compounds 3, 2 and 1 (each within the scatter of the next).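

With hexyloxy in place of isobutyl on an aromatic carbon, para to a large group, this assay gives a step that stays within the scatter (a 1.3-fold lower number from compound 2 to compound 3 (0.11 log units; within the scatter)), even though the entering group has 7 heavy atoms against 4 and brings a hydrogen-bond acceptor. The comparison within the alkoxy chains, ethyl in place of hydrogen on a saturated chain carbon, four bonds along the chain from an oxygen on an aromatic ring, also stays within the scatter (a 1.6-fold lower number from compound 1 to compound 3 (0.21 log units; within the scatter)), so butoxy, isobutyl and hexyloxy cannot be told apart at this position, and no data shown explain this.

On these data alone, whether a chain longer than hexyloxy would move the number beyond the scatter remains open. The same holds for an amine or a carboxylic acid on this aromatic carbon, since all three compounds shown carry uncharged chains there.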